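Replacing 2-chlorophenyl on the amine nitrogen of compound 1

The source may report more compounds than this note shows. Statements on the series, on what has been measured and on what is new or still open speak of the compounds shown alone.

In a functional assay on SGC-7901 cells (Homo sapiens) for antiproliferative activity, read by MTT assay, with a stated time of 24 h (on this read-out lower numbers stand for stronger inhibition and higher numbers for weaker inhibition), compound 1 `O=C(NNc1ccccc1Cl)c1ccc(NS(=O)(=O)c2cnc(O)nc2O)cc1` gives 3630 nM and compound 2 `O=C(NNc1ccccc1Cl)c1cccc(NS(=O)(=O)c2cnc(O)nc2O)c1` gives 2270 nM. Among the compounds with values here, these two values lie within the scatter of each other, so compound 1 stands level with its only measured neighbour. Compound 3 `Cc1ccc(C(=O)NNC(=O)c2ccc(NS(=O)(=O)c3cnc(O)nc3O)cc2)cc1` carries (4-methylphenyl)carbonyl in place of 2-chlorophenyl on an amine nitrogen. Within the data shown here, no measured pair covers this change, so the data give no direction for it. In this assay no shift beyond the scatter is expected, and the estimated step is a 1.2-fold lower number from compound 1 to compound 3 (0.08 log units; within the scatter). For compound 3 the estimated value is 3000 nM, with an expected range of 900 nM to 10000 nM.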

Compound 3, half-maximal inhibitory concentration: > 20000 nM
Compound 3: a limit, no number; the forecaster's own chance of this, stated with the estimate: 5%; middle value at least 6.6-fold (0.82 log units) away from the limit.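

In this assay, the amine nitrogen carrying 2-chlorophenyl proves sensitive to substitution: (4-methylphenyl)carbonyl at this place gives an at least 5.5-fold higher number from compound 1 to compound 3 (0.74 log units; beyond the scatter). This is the first shift beyond the scatter shown for the series, and its true size remains unknown. The read-out for compound 3 is a limit, not a number: the limit of > 20000 nM in this assay, at which 1 of the 3 values shown sits.

Still open, going by these compounds, is whether the carbonyl, the methyl group or the loss of chlorine accounts for the shift. Also open, on these data alone, is how an unsubstituted phenyl or a benzyl group on this nitrogen would compare with compound 1.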